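Fluoro for methyl on the 4-methylphenyl of compound 2

This account rests on a few compounds, and the source may have more. Where it says the series, first, only, none or still open, it means among the compounds named here.

Among the measured compounds shown here, compound 2 `Cc1ccc(-c2ccnc(C(=O)Nc3ccc(Oc4ccnc5[nH]ccc45)c(F)c3)c2)cc1` is the only member of the series with a numerical reading: in a functional assay on MCF7 cells (Homo sapiens) for cytotoxicity, read by MTT assay, with a stated time of 72 h (a lower number here means a stronger inhibitor, a higher number a weaker inhibitor), compound 2 gives 8430 nM. Compound 1 `O=C(Nc1ccc(Oc2ccnc3[nH]ccc23)c(F)c1)c1cc(-c2ccccc2)ccn1` reaches only the limit of this assay, where compound 1 gives > 10000 nM. For the measured compounds named here, the single measured step, an at least 1.1-fold lower number from compound 1 to compound 2 (0.07 log units; that floor lies within the scatter), is a methyl in place of hydrogen on an aromatic carbon and lies within the scatter, one end of it resting on the limit (the limit of > 10000 nM in this assay, at which 1 of the 2 values shown sits). Compound 3 `O=C(Nc1ccc(Oc2ccnc3[nH]ccc23)c(F)c1)c1cc(-c2ccc(F)cc2)ccn1` carries the change (fluoro in place of methyl on an aromatic carbon), read one bond further out as 4-methylphenyl to 4-fluorophenyl. Going by the values given here, no measured step touches fluoro, so the only step bearing on this change is the methyl one, which is small and partly a limit. A step of similar size in either direction, or none beyond the scatter, is therefore expected in this assay. Compound 3 is estimated at 10000 nM, within 4000 nM to 25000 nM. The expected step is a 1.2-fold higher number from compound 2 to compound 3 (0.07 log units; within the scatter).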

Compound 3, half-maximal inhibitory concentration: 9520 nM
For compound 3 the middle estimate is 1.1-fold (0.02 log units) above the measured one, and the stated range covers the measured number.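

In this assay, fluoro in place of methyl on an aromatic carbon, para to a large group, gives a 1.1-fold higher number from compound 2 to compound 3 (0.05 log units; within the scatter), so this position now has two numerical readings, and they do not separate the 4-methylphenyl from the 4-fluorophenyl. Fluoro in place of hydrogen at the same place gives an at least 1.0-fold lower number from compound 1 to compound 3 (0.02 log units; that floor lies within the scatter), which rests on a limit and therefore sets only a floor. Compound 1 is a limit and not a number, so the comparison with hydrogen stays unresolved because of where that value sits: the limit of > 10000 nM in this assay, at which 1 of the 3 values shown sits.

The compounds shown leave open whether an amine, a carboxylic acid or a methoxy group at this position would move the number beyond the scatter. They also leave open whether any change on the shared core would do so.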